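Carbonyl substituent exchange for nitro in a phospholipase series

The source may report more compounds than this note shows. Statements on the series, on what has been measured and on what is new or still open speak of the compounds shown alone.

Measured so far:
compound 1 `CCOc1ccc(-c2cccc(C(=O)OCCOC)c2)cc1`, 89%
compound 2 `CCOc1ccc(-c2cccc(C(=O)N3CCCC3)c2)cc1`, 53%

In an assay on COS-7 cells for inhibition of patatin-like phospholipase domain-containing protein 2 (Mus musculus), tested at 200 uM (on this read-out higher numbers stand for more inhibition at the one concentration tested (going by the name of the read-out) and lower numbers for less inhibition), compound 1 gives 89%, and compound 2 gives 53%. Among the compounds with values here, compound 2 stands lowest of the two numbers; the only measured step, a number 36 percentage points lower from compound 1 to compound 2 (beyond the scatter), is beyond the scatter and large.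

Compound 3 `CCOc1ccc(-c2cccc([N+](=O)[O-])c2)cc1` differs from compound 2 in that (nitro in place of (pyrrolidin-1-yl)carbonyl on an aromatic carbon). Within the data shown here, no measured step replaces a carbonyl group with nitro, so the one step bears only loosely on it; it shows that exchanging the group on this aromatic carbon can move the read-out a great deal in either direction. Compound 3 is expected at 55%, with a range from 20% to 85%. The step expected for compound 3 is a number 2 percentage points higher from compound 2 to compound 3 (within the scatter), not resolved beyond the scatter.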

Compound 3, a percentage reported as inhibition, at one concentration (the size of the read-out at that concentration, not a potency): 35%
The estimate for compound 3 lay 20 percentage points above the measured number; the measured number falls inside the stated range.
By their numbers in this assay, from the lowest: compound 3; then compound 2; then compound 1.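

In this assay, nitro in place of (pyrrolidin-1-yl)carbonyl gives a number 18 percentage points lower from compound 2 to compound 3 (beyond the scatter), and nitro in place of (2-methoxyethoxy)carbonyl gives a number 54 percentage points lower from compound 1 to compound 3 (beyond the scatter). Both carbonyl-bearing groups therefore stand higher than nitro on this aromatic carbon, and all three compounds are now separated beyond the scatter. Nothing available explains this order. Still open, going by these compounds, is where a carboxylic acid or an amine on this aromatic carbon would fall relative to these three compounds. Also open, on these data alone, is whether an ester with a longer chain would stay near compound 1.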